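Working notes: from compound 3 to compound 4

The compounds below may be only part of what the source reports. "The series", "measured", "known", "first", "only" and "open" are said of these compounds alone.

Measured in a functional assay on HOS-TE85 cells (Homo sapiens) for inhibition, read by CCK-8 assay, with a stated time of 72 h; on this read-out higher numbers stand for weaker inhibition and lower numbers for stronger inhibition
- compound 1 `COc1ccc(C)cc1N1C(=O)CSC1c1cccc(C(=O)NCCCCc2ccccc2)c1` gives 300 nM
- compound 2 `COc1ccc(OC)c(N2C(=O)CSC2c2cccc(C(=O)NCCCCc3ccccc3)c2)c1` gives only a limit (> 1000 nM)
- compound 3 `O=C(NCCCCc1ccccc1)c1cccc(C2SCC(=O)N2c2cccc(-c3c[nH]nn3)c2)c1` gives 110 nM

Compound 3 holds the lowest number of the series (110 nM). Compound 4 (`C#Cc1cccc(N2C(=O)CSC2c2cccc(C(=O)NCCCCc3ccccc3)c2)c1`) differs from it as follows: ethynyl in place of 1H-1,2,3-triazol-4-yl on an aromatic carbon. For the measured compounds named here, no measured step makes this exchange directly. The closest steps replace the whole aromatic group on the amide-type nitrogen in a ring (a 2.7-fold lower number from compound 1 to compound 3 (0.44 log units; beyond the scatter); an at least 9.0-fold lower number from compound 2 to compound 3 (0.95 log units; beyond the scatter)). A single swap of methyl for methoxy also moves the number beyond the scatter (an at least 3.3-fold higher number from compound 1 to compound 2 (0.52 log units; beyond the scatter)). With compound 1 (300 nM) as nearest neighbour lacking the 1H-1,2,3-triazol-4-yl, a modest rise is expected. The expected step is a 2.3-fold higher number from compound 3 to compound 4 (0.36 log units; beyond the scatter). For compound 4 the estimated value is 250 nM (expected range 80 nM to 800 nM).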

Compound 4, half-maximal inhibitory concentration: 149 nM
The estimate for compound 4 lay 1.7-fold (0.22 log units) above the measured number; the range from low to high includes it.
By their numbers in this assay, from the lowest: compounds 3, 4 and 1 (each within the scatter of the next, the first and the last beyond it). At a limit, above all of these: compound 2.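

In this assay ethynyl replaces 1H-1,2,3-triazol-4-yl on this aromatic carbon with a 1.4-fold higher number from compound 3 to compound 4 (0.13 log units; within the scatter) and so the five-membered aromatic ring and its hydrogen-bond donor are not required for a number of this size. Against the earlier aromatic groups, 3-ethynylphenyl gives a 2.0-fold lower number from compound 1 to compound 4 (0.30 log units; within the scatter) and an at least 6.7-fold lower number from compound 2 to compound 4 (0.82 log units; beyond the scatter) on the amide-type nitrogen in a ring. The second of these steps rests on the value of compound 2, which is a limit: the limit of > 1000 nM in this assay, at which 1 of the 4 values shown sits.

From the compounds shown here alone, whether a nitrile, a carboxylic acid or an amine on this aromatic carbon would stay in the same range remains open. So does the effect of a longer chain in place of ethynyl.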